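Notes on the step from compound 1 to compound 4

A few compounds are considered here, and "the series" means these few. Any claim that something is new, unique, unknown or untested is made for them only; others in the source may bear on it.

In an ADME assay on RAW264.7 cells (Mus musculus) for cytotoxicity, read by MTT assay, with a stated time of 24 h, in the absence of a further agent (a higher number here means a weaker inhibitor, a lower number a stronger inhibitor), compound 1 `CCOc1ccc(C(O)C2OC(=O)c3c(OC)cc(OC)cc32)cc1` gives > 40000 nM, which is a limit of the assay rather than a number. Compound 2 `COCCOc1ccc(C(O)C2OC(=O)c3c(OC)cc(OC)cc32)cc1` gives > 40000 nM, again a limit. Compound 3 `COc1cc(OC)c2c(c1)C(C(O)c1ccc(OCCOc3ccccc3)cc1)OC2=O` gives > 40000 nM, also a limit. Among the measured compounds shown here, compound 1 therefore stands nowhere apart from its neighbours: all three measured values sit at the limit of > 40000 nM in this assay, at which 3 of the 3 values shown sit, and no compound is separated from another. The steps a step that the two limits leave unreadable from compound 1 to compound 2, a step that the two limits leave unreadable from compound 1 to compound 3 and a step that the two limits leave unreadable from compound 2 to compound 3 are unreadable for that reason, whether methoxy, phenoxy or phenyl is introduced on the chain hanging from the aromatic oxygen.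

Compound 4 `COc1cc(OC)c2c(c1)C(C(O)c1ccc(OCc3ccc(OC(F)F)cc3)cc1)OC2=O` differs from compound 1 by 4-(difluoromethoxy)phenyl in place of methyl on a saturated chain carbon bound to an oxygen on an aromatic ring. The steps from compound 1 to compound 2 and from compound 1 to compound 3 bear on it most closely, since each also grows the same chain, and neither gave a readable size. For the measured compounds named here, no measured step indicates any direction beyond the scatter in this assay, so compound 4 is expected to behave like the three measured compounds, and the step that the limit leaves unreadable from compound 1 to compound 4 is expected to be small. Compound 4 is thus estimated at 50000 nM, within 20000 nM to 150000 nM, most probably reported as a limit.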

Compound 4, half-maximal inhibitory concentration: > 40000 nM
Compound 4: no number, only a limit; the forecaster's own chance of this, stated with the estimate: 80%; the middle value is on the limit's open side.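

No step from compound 4 to compound 1, compound 2 or compound 3 can be read, because all four compounds share one limit of the assay and none is separated from another: the limit of > 40000 nM in this assay, at which 4 of the 4 values shown sit.

The compounds shown leave open whether any group on the saturated chain carbon bound to an oxygen on an aromatic ring alters the read-out in this assay.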